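Lengthening a Sulfonamide Chain by One Carbon

This account rests on a few compounds, and the source may have more. Where it says the series, first, only, none or still open, it means among the compounds named here.

Of the compounds shown here, three sharing one core have been tested in a functional assay on HeLa cells (Homo sapiens) for antiproliferative activity, read by CCK-8 assay, with a stated time of 72 h; on this read-out lower numbers stand for stronger inhibition of growth and higher numbers for weaker inhibition of growth. Compound 1 `CCCNS(=O)(=O)c1ccc(Nc2ncc3c(n2)N(C2CCCC2)[C@H](CC)C(=O)N3C)cc1` gives 459 nM, the second highest of the three numbers. Compound 3 `CC[C@@H]1C(=O)N(C)c2cnc(-n3ccc4cc(C(=O)NC5CCCC5)ccc43)nc2N1C1CCCC1` gives 247 nM, and its distance from compound 1 lies within the scatter of repeated measurements, so the two cannot be told apart. Compound 2 `CCC1C(=O)N(C)c2cnc(Nc3ccc(S(=O)(=O)NCC(C)C)cc3)nc2N1c1ccn(C)n1` gives 5310 nM, a weaker inhibition of growth than compound 1 by a margin beyond the scatter.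

The next compound, compound 4 `CCCCNS(=O)(=O)c1ccc(Nc2ncc3c(n2)N(C2CCCC2)[C@H](CC)C(=O)N3C)cc1`, has not yet been measured in this assay. It differs from compound 1 in one place: methyl in place of hydrogen on a saturated chain carbon, three bonds along the chain from a sulfonamide nitrogen. For the measured compounds named here, no pair of measured compounds differs only in this way, so nothing measured here tracks the change directly. Going from propyl to butyl is a small change, and the expected step of a 1.1-fold lower number from compound 1 to compound 4 (0.04 log units; within the scatter) in this assay is estimated to be no larger than the scatter, with no set direction. Compound 4 is therefore expected to give about 420 nM, with a likely range from 200 nM to 900 nM.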

Compound 4, concentration for 50% growth inhibition: 451 nM
Compound 4: the middle estimate sits 1.1-fold (0.03 log units) below what was measured; the measured number falls inside the stated range.
By their numbers in this assay, from the lowest: compounds 3, 4 and 1 (each within the scatter of the next); then compound 2.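

Adding a methyl at this spot, on a saturated chain carbon three bonds along the chain from a sulfonamide nitrogen, turns propyl into butyl and gives a 1.0-fold lower number from compound 1 to compound 4 (0.01 log units; within the scatter) in this assay. For the compounds shown here, this is the first direct reading of this change: with the rest of the molecule held constant, the two compounds cannot be told apart, so this position accepts one more carbon with no detectable difference in growth inhibition. Nothing available explains why the two compounds read alike.

The compounds shown leave open whether this holds further out, for a longer chain such as hexyl or a chain ending in an amine or a carboxylic acid. They also leave open whether a shorter chain, such as methyl or ethyl, would read the same.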